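The source may hold more compounds than are shown below. What is called first, only, known or untested is meant among the compounds shown, and "the series" means these compounds.

Of the compounds shown here, three built on one shared core have been measured in a functional assay on isolated protein for inhibition of Glucose-dependent insulinotropic receptor (Rattus norvegicus), read by HTRF and cAMP accumulation; a lower number here means a smaller maximal response, a higher number a larger maximal response. Compound 1 `Cc1nc(S(C)(=O)=O)ccc1Oc1ncnc(OC2CCN(C(=O)O[C@@H](C)C(F)(F)F)CC2)c1F` gives 80% in this assay. Compound 2 `Cc1nc(S(C)(=O)=O)ccc1Oc1ncnc(OC2CCN(C(=O)OC3(C(F)(F)F)COC3)CC2)c1F` gives 84% in this assay, and compound 3 `Cc1nc(S(C)(=O)=O)ccc1Oc1ncnc(OC2CCN(C(=O)SC3(C)CC3)CC2)c1F` gives 77% in this assay. On these numbers compound 3 stands closest to one neighbour through a number 3 percentage points lower from compound 1 to compound 3 (within the scatter) and furthest from the other through a number 7 percentage points lower from compound 2 to compound 3 (within the scatter); both gaps fall within the usual scatter, so the three numbers cannot be separated from one another.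

The next step leads to compound 4 `Cc1nc(S(C)(=O)=O)ccc1Oc1ncnc(OC2CCN(C(=O)C3CCCC3)CC2)c1F`. The change is a group of 5 heavy atoms (5 carbon; one five-membered non-aromatic ring of carbon only) in place of a group of 5 heavy atoms (4 carbon, 1 sulfur; one three-membered non-aromatic ring of carbon only), on a carbonyl carbon. Among the compounds with values here, two measured steps bear on it, since each also exchanges the group on the carbonyl carbon: a number 3 percentage points lower from compound 1 to compound 3 (within the scatter) and a number 7 percentage points lower from compound 2 to compound 3 (within the scatter), both within the scatter. The remaining measured step, a number 4 percentage points higher from compound 1 to compound 2 (within the scatter), stayed within the scatter as well. Nothing among the three measured compounds therefore points to a step beyond the scatter in this assay, in either direction, when the group on the carbonyl carbon is exchanged once more. Compound 4 is accordingly expected to give 79%, with a range from 67% to 91%. The expected step is a number 2 percentage points higher from compound 3 to compound 4 (within the scatter).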

Compound 4, largest response reached (reported as efficacy), in percent of the reference or control that the assay uses: 83%
Estimate against measurement, compound 4: 4 percentage points below; the measured number falls inside the stated range.
By their numbers in this assay, from the lowest: compounds 3, 1, 4 and 2 (each within the scatter of the next).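

In this assay, within the data shown here, compound 4 is the first of the series in which the carbonyl carbon carries a carbon-linked group, cyclopentyl, while compound 1, compound 2 and compound 3 all carry a group linked through oxygen or sulfur. Set against the sulfur-linked group, the exchange gives a number 6 percentage points higher from compound 3 to compound 4 (within the scatter) and, set against the two oxygen-linked groups, it gives a number 3 percentage points higher from compound 1 to compound 4 (within the scatter) and a number 1 percentage points lower from compound 2 to compound 4 (within the scatter) in turn. Among these four compounds, then, a linking oxygen or sulfur on the carbonyl carbon is not required to keep the maximal response within the scatter, and no exchange at this place has yet separated one compound from another. Nothing available explains these numbers.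

The compounds shown leave open whether this tolerance extends to an amine on the carbonyl carbon, to a phenyl ring or to a longer chain such as n-butyl. They also leave open whether any group at this place would move the maximal response beyond the scatter, in either direction.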